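3-Oxomorpholin-4-yl in Place of Acetyl(methyl)amino

This account rests on a few compounds, and the source may have more. Where it says the series, first, only, none or still open, it means among the compounds named here.

In an assay on CHO cells for agonist activity at Glucose-dependent insulinotropic receptor (Homo sapiens), read by a luciferase reporter and cAMP accumulation, with a stated time of 2 h (a lower number here means that less compound is needed, a higher number that more compound is needed for the effect), compound 1 `CC(C)c1noc(N2CCC(Oc3cc(N4CCc5cc(C6CCCCC6=O)ccc54)ncn3)CC2)n1` gives 48 nM.
In this assay, compound 2 `CC(=O)N(C)c1ccc2c(c1)CCN2c1cc(OC2CCN(c3nc(C(C)C)no3)CC2)ncn1` gives 75 nM.

Compound 2 carries the higher of the two numbers, but the step of a 1.6-fold higher number from compound 1 to compound 2 (0.19 log units; within the scatter) lies within the scatter, so the two compounds cannot be ordered on these data. Compound 3 `CC(C)c1noc(N2CCC(Oc3cc(N4CCc5cc(N6CCOCC6=O)ccc54)ncn3)CC2)n1` differs from compound 2 in one place: 3-oxomorpholin-4-yl in place of acetyl(methyl)amino on an aromatic carbon. Among the compounds with values here, only one measured step bears on this position, a 1.6-fold higher number from compound 1 to compound 2 (0.19 log units; within the scatter), and it did not move the number beyond the scatter even though the whole group at that carbon was exchanged. Within the data shown here, the group entering in compound 3, like the one leaving, contains a carbonyl, and with the single comparison available no step beyond the scatter is expected. Compound 3 is therefore estimated at 60 nM, with a range from 25 nM to 180 nM, which amounts to an expected step of a 1.3-fold lower number from compound 2 to compound 3 (0.10 log units; within the scatter).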

Compound 3, half-maximal effective concentration: 15 nM
The estimate for compound 3 lay 4.0-fold (0.60 log units) above the measured number; the measured number lies below the stated range.
By their numbers in this assay, from the lowest: compound 3; then compounds 1 and 2 (each within the scatter of the next).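

In this assay, within the data shown here, this aromatic carbon proves sensitive to the group it carries: 3-oxomorpholin-4-yl in place of acetyl(methyl)amino gives a 5.0-fold lower number from compound 2 to compound 3 (0.70 log units; beyond the scatter), and the same group in place of 2-oxocyclohexyl gives a 3.2-fold lower number from compound 1 to compound 3 (0.51 log units; beyond the scatter), whereas the only earlier step at this carbon stayed within the scatter. Of the three compounds, only compound 3 has a six-membered non-aromatic ring with 2 hetero atoms at this carbon, and both of its steps are modest. No measurement is available that would explain the difference.

The compounds shown include neither 2-oxopiperidin-1-yl nor morpholin-4-yl at this carbon, so it remains open whether the ring oxygen, the carbonyl or both go with the lower number. As far as these compounds go, how a carboxylic acid or a primary amine would read at this carbon also remains open.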